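Hydroxyphenyl urea analogues of a quinoline core in HeLa cells

A few compounds are considered here, and "the series" means these few. Any claim that something is new, unique, unknown or untested is made for them only; others in the source may bear on it.

Measured compounds:
compound 1 `COc1cc(NC(C)CCCNC(=O)Nc2ccc(O)cc2)c2ncccc2c1` — 70000 nM
compound 2 `COc1cc(NC(C)CCCNC(=O)NNC(=O)Nc2ccc(C(F)(F)F)cc2)c2ncccc2c1` — 15000 nM

Of the compounds shown here, two have been tested in a functional assay on HeLa cells (Homo sapiens) for inhibition, read by MTT assay, with a stated time of 72 h; a higher number here means a weaker inhibitor, a lower number a stronger inhibitor. Compound 1 gives 70000 nM and compound 2 gives 15000 nM; compound 1 stands at the highest of the two numbers, and the gap to compound 2 is beyond the scatter. Compound 3 `COc1cc(NC(C)CCCNC(=O)Nc2cccc(O)c2)c2ncccc2c1` has not yet been measured in this assay. It differs from compound 1 in one place: 3-hydroxyphenyl in place of 4-hydroxyphenyl on an amide-type nitrogen. The same atoms are present in both, joined differently. For the measured compounds named here, no measured pair shows this kind of change, so there is no step to lean on, and the writer expects at most a modest shift in either direction from compound 1 to compound 3, probably none beyond the scatter, as a 1.2-fold lower number from compound 1 to compound 3 (0.07 log units; within the scatter). Compound 3 is therefore estimated at 60000 nM in this assay, within a range of 25000 nM to 150000 nM.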

Compound 3, half-maximal inhibitory concentration: 48000 nM
The estimate for compound 3 lay 1.3-fold (0.10 log units) above the measured number; the measured number falls inside the stated range.
By their numbers in this assay, from the lowest: compound 2; then compounds 3 and 1 (each within the scatter of the next).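

Exchanging 4-hydroxyphenyl for 3-hydroxyphenyl on the amide-type nitrogen gives the only one-place comparison shown in this assay, and it reads as a 1.5-fold lower number from compound 1 to compound 3 (0.16 log units; within the scatter). At this place, then, the two hydroxyphenyl groups cannot be told apart in this assay, even though they carry the hydroxyl at different ring positions. No measurement on hand offers an explanation for this result.

From the compounds shown here alone, whether the hydroxyl itself matters remains open, as does whether a plain phenyl, an aminophenyl or a carboxylic acid on the phenyl ring would shift the number beyond the scatter. Compound 2 differs from compound 1 and compound 3 in more than one place, so the contribution of its trifluoromethylphenyl group or its longer linker cannot be separated.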